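Triphenyl acid series: carboxymethoxy in place of carboxymethyl

The compounds below may be only part of what the source reports. "The series", "measured", "known", "first", "only" and "open" are said of these compounds alone.

Values in a functional assay for inhibition, with Homo sapiens as the target; on this read-out lower numbers stand for stronger inhibition and higher numbers for weaker inhibition:
- compound 1 `O=C(O)CCCCCCCn1nc(-c2ccccc2)c(-c2ccccc2)c1-c1ccccc1`: 3400 nM
- compound 2 `O=C(O)CCCCCCCCn1cc(-c2ccccc2)cn1`: > 105000 nM (a limit)
- compound 3 `O=C(O)CCCCCCCn1cc(-c2ccccc2)c(-c2ccccc2)n1`: > 85000 nM (a limit)

Among the measured compounds shown here, compound 1 is the only compound here with a number, 3400 nM. The other two entries are limits, so there is no ranking among the three beyond that.

The next compound to be measured is compound 4 `O=C(O)COCCCCCCn1nc(-c2ccccc2)c(-c2ccccc2)c1-c1ccccc1`. It keeps the core of compound 1 and carries carboxymethoxy in place of carboxymethyl on a saturated chain carbon, six bonds along the chain from an aromatic nitrogen.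

One measured step is available, an at least 25-fold higher number from compound 1 to compound 3 (1.39 log units; beyond the scatter). It is large, but it is hydrogen in place of phenyl on an aromatic carbon and leaves the chain as it is. It therefore bears on the change only indirectly, as a sign that this assay can respond sharply within this series. For the measured compounds named here, no measured step covers a change at this place in the chain.

The expectation therefore stays close to the value of compound 1, with no step beyond the scatter in either direction. The expected step is a 1.4-fold lower number from compound 1 to compound 4 (0.13 log units; within the scatter). For compound 4 the estimate is 2500 nM, with an expected range of 700 nM to 12000 nM.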

Compound 4, half-maximal inhibitory concentration: 440 nM
Compound 4: middle estimate off by 5.7-fold (0.75 log units), on the high side; measured number below the stated range.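

In this assay the chain proves to be a place that responds in its own right: carboxymethoxy in place of carboxymethyl, on a saturated chain carbon, six bonds along the chain from an aromatic nitrogen, gives a 7.7-fold lower number from compound 1 to compound 4 (0.89 log units; beyond the scatter) with the core of compound 1 unchanged. The one earlier step, an at least 25-fold higher number from compound 1 to compound 3 (1.39 log units; beyond the scatter) on hydrogen in place of phenyl on an aromatic carbon, left the chain as it is and went only towards a higher number, so this is the first change shown to go towards a lower number than that of compound 1. Nothing in the data at hand accounts for the size of this step, which remains an observation on a single pair.

Compound 4 is the only compound shown with an oxygen in the chain, so it stays open whether the step belongs to that oxygen or to its place, and a sulfur or an amine nitrogen at the same place, or the oxygen moved along the chain, would separate the two. Also open, going by these compounds, is how much depends on the acid end itself, which a tetrazole or a primary amide in place of the carboxylic acid would test.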